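A few compounds are considered here, and "the series" means these few. Any claim that something is new, unique, unknown or untested is made for them only; others in the source may bear on it.

Compound 1 `COc1ccc(-c2noc(-c3ccc(OC)cc3)c2C)cc1` and compound 2 `CCc1c(-c2ccc(OC)cc2)noc1-c1ccc(OC)cc1` share a core and differ in one place, (methyl in place of hydrogen on a saturated chain carbon bound to an aromatic carbon). In an ADME assay (Mus musculus) for antiproliferative activity, read by cell counting, with a stated time of 5 days (a lower number here means a stronger inhibitor, a higher number a weaker inhibitor), compound 1 gives > 100000 nM, which is a limit of the assay rather than a number. Compound 2 likewise gives > 100000 nM in this assay, again a limit. The step that the two limits leave unreadable from compound 1 to compound 2 therefore cannot be read, because of the limit of > 100000 nM in this assay, at which 2 of the 3 values shown sit. Compound 3 `Cc1c(-c2ccc(O)cc2)noc1-c1ccc(O)cc1` has a core of its own; the difference between its core and that of compound 1 is not broken down here. In this assay, among the measured compounds shown here, compound 3 gives 19000 nM, the only number among the three values. Compound 4 `CCc1c(-c2ccc(O)cc2)noc1-c1ccc(O)cc1`, not yet measured, differs from compound 3 by the same change, (methyl in place of hydrogen on a saturated chain carbon bound to an aromatic carbon). For the measured compounds named here, the one measured instance of that change, from compound 1 to compound 2, sits at limits on both sides and offers no size to lean on, so compound 4 can only be expected to stay close to compound 3. The estimated step of a 1.3-fold higher number from compound 3 to compound 4 (0.12 log units; within the scatter) is accordingly expected to be modest. The estimate for compound 4 in this assay is 25000 nM, expected to fall between 8000 nM and 80000 nM.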

Compound 4, half-maximal inhibitory concentration: 13000 nM
The estimate for compound 4 lay 1.9-fold (0.28 log units) above the measured number; the measured number falls inside the stated range.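

In this assay, the change on the core of compound 3 gives a 1.5-fold lower number from compound 3 to compound 4 (0.16 log units; within the scatter), so putting methyl in place of hydrogen on a saturated chain carbon bound to an aromatic carbon, which turns methyl to ethyl, has no effect beyond the scatter on this core. The same change on the core of compound 1 offers no size to compare with it, because compound 1 and compound 2 both sit at a limit of the assay rather than at a number: the limit of > 100000 nM in this assay, at which 2 of the 4 values shown sit. Among the compounds shown here, the series therefore holds only one readable instance of the change, and it does not show whether the change carries from one core to the other with the same size.

The compounds shown leave open whether a longer chain such as propyl, or an amine or a carboxylic acid on that chain, would move the number beyond the scatter on the core of compound 3. Also open, from the compounds shown here alone, is what size the change has on the core of compound 1.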